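Benzyl for (pyridin-2-yl)methyl on the cyclic amide nitrogen

The source may report more compounds than this note shows. Statements on the series, on what has been measured and on what is new or still open speak of the compounds shown alone.

Measured compounds in an in vitro ADME assay on microsomes from liver (Homo sapiens) for metabolic stability; a higher number here means that the compound lasts longer, a lower number that the compound disappears faster:
- compound 1 `CS(=O)(=O)Nc1ccc2c(c1)S(=O)(=O)N=C(C1=C(O)C3CCCC3N(Cc3ccccn3)C1=O)N2` gives > 1 h, a limit of the assay.
- compound 2 `CC(C)(C)CCN1C(=O)C(C2=NS(=O)(=O)c3cc(NS(C)(=O)=O)ccc3N2)=C(O)C2CCCCC21` gives 0.267 h.
- compound 3 `CS(=O)(=O)Nc1ccc2c(c1)S(=O)(=O)N=C(C1=C(O)[C@H]3CCC[C@H]3N(CC3CC3)C1=O)N2` gives > 1 h, again a limit of the assay.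

Compound 1 stands at the limit of > 1 h in this assay, at which 2 of the 3 values shown sit, so only a limit is known for it, not a number. Going by the values given here, compound 2 is the one measured value that falls below that limit. Among the compounds with values here, no pair of measured compounds differs in one place, so no measured step is available for this series.

Compound 4 `CS(=O)(=O)Nc1ccc2c(c1)S(=O)(=O)N=C(C1=C(O)C3CCCC3N(Cc3ccccc3)C1=O)N2` has not yet been measured in this assay. It differs from compound 1 by phenyl in place of pyridin-2-yl on a saturated chain carbon bound to an amide-type nitrogen in a ring. Without a measured step to rest on, the expectation for this assay is a step from compound 1 that stays within the usual scatter or is a modest decrease, with the change an at least 1.2-fold lower number from compound 1 to compound 4 (0.09 log units; that floor lies within the scatter) expected. The half-life of compound 4 is accordingly estimated at 0.8 h, within a range of 0.35 h to 1.5 h.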

Compound 4, half-life: 0.833 h
The estimate for compound 4 lay 1.0-fold (0.02 log units) below the measured number; the range from low to high includes it.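

Going by these compounds alone, the first measured step at this place is an at least 1.2-fold lower number from compound 1 to compound 4 (0.07 log units; that floor lies within the scatter). In this assay compound 1 gives > 1 h, which is a limit of the assay and not a number. The change from (pyridin-2-yl)methyl to benzyl therefore has a floor but no upper bound, because compound 1 sits at that limit: the limit of > 1 h in this assay, at which 2 of the 4 values shown sit.

Within the data shown here, how far compound 1 lies beyond its limit stays open, so the full size of this step cannot be read, and compound 2 and compound 3 differ from compound 4 in more than one place and give no further step. Also open, from the compounds shown here alone, is how an amine or a carboxylic acid in place of phenyl, on the saturated chain carbon bound to the amide-type nitrogen in the ring, would read in this assay.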